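The source may report more compounds than this note shows. Statements on the series, on what has been measured and on what is new or still open speak of the compounds shown alone.

Three related compounds have been tested in a functional assay on HeLa cells (Homo sapiens) for inhibition, read by MTT assay, with a stated time of 24 h; a lower number here means a stronger inhibitor, a higher number a weaker inhibitor: compound 1 `C/C=C(\C)C(=O)O[C@@H]1C(=O)/C=C2/C3=CC(=O)O[C@@H](c4ccoc4)[C@]3(C)CC[C@@H]2[C@@]2(C)C(=O)C[C@]1(C)[C@@H]2[C@@H](O)C(=O)OC`, compound 2 `C/C=C(\C)C(=O)O[C@H]1[C@]2(C)C[C@@H]3O[C@@]1(O)C=C1C4=CC(=O)O[C@@H](c5ccoc5)[C@]4(C)CC[C@@H]1[C@]3(C)[C@@H]2C(=O)C(=O)OC` and compound 3 `C/C=C(\C)C(=O)O[C@@H]1[C@]2(OC(=O)CCCC)C=C3C4=CC(=O)O[C@@H](c5ccoc5)[C@]4(C)CC[C@@H]3[C@@]3(C)[C@H](C[C@]1(C)[C@H]3[C@@H](OC(=O)CCCC)C(=O)OC)O2`. Compound 1 gives > 100000 nM, which is a limit of the assay and not a number. Compound 2 gives > 100000 nM, again a limit. Compound 3 gives > 100000 nM, also a limit. Among the compounds with values here, the series so far therefore shows (the limit of > 100000 nM in this assay, at which 3 of the 3 values shown sit). Compound 3 has no exact place on the scale, and none of the three can be ranked against another in this assay.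

The next compound, compound 4 `C/C=C(\C)C(=O)O[C@@H]1[C@]2(OC(=O)CCCC)C=C3C4=CC(=O)O[C@@H](c5ccoc5)[C@]4(C)CC[C@@H]3[C@@]3(C)[C@H](C[C@]1(C)[C@H]3[C@@H](O)C(=O)OC)O2`, differs from compound 3 in one place, with hydrogen in place of butylcarbonyl on an oxygen on a saturated carbon. In other words, one (butylcarbonyl)oxy becomes hydroxy. Within the data shown here, no measured pair shows what this change does on its own. Resting on compound 3, which stands at the limit > 100000 nM, the expectation in this assay is no step beyond the usual scatter and no clear direction. The estimated change is a number no higher from compound 3 to compound 4 (the limit leaves the size open). A reported limit is the most likely outcome, and as a number the estimate for compound 4 is 100000 nM, with an expected range from 40000 nM to 200000 nM.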

Compound 4, half-maximal inhibitory concentration: > 100000 nM
Compound 4: no number, only a limit; the forecaster's own chance of this, stated with the estimate: 80%; the middle value sits exactly at the limit.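

Compound 4 gives > 100000 nM, which is a limit of the assay and not a number. Compound 3 sits at a limit too, so no step can be read between compound 3 and compound 4 in this assay. Every value shown stays at this ceiling: the limit of > 100000 nM in this assay, at which 4 of the 4 values shown sit.

What the compounds leave open is whether any change to the shared core moves the value in this assay at all.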